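The source may report more compounds than this note shows. Statements on the series, on what has been measured and on what is new or still open speak of the compounds shown alone.

Compound 1 `CCCCCCCCCCC#Cc1cc2cn([C@@H]3O[C@H](CO)[C@@H](O)[C@@H]3O)c(=O)nc2o1`: 46000 nM
Compound 2 `CCCCCCCCCCC#Cc1cc2cn([C@H]3C[C@H](O)[C@@H](CO)O3)c(=O)nc2o1`: 30000 nM
Compound 3 `CCCCCCCCC#Cc1cc2cn([C@H]3C[C@H](O)[C@@H](CO)O3)c(=O)nc2o1`: 52000 nM

Of the compounds shown here, three sharing one core have been tested in a functional assay on HEL cells (Homo sapiens) for cytotoxicity; on this read-out higher numbers stand for lower toxicity in this test and lower numbers for higher toxicity in this test. Compound 2 differs from compound 1 only by the change (hydroxy in place of hydrogen on a saturated ring carbon); that change gave a 1.5-fold higher number from compound 2 to compound 1 (0.19 log units; within the scatter), a step that stays within the scatter of this kind of measurement. Compound 2 and compound 3 differ in the chain instead, by the change (hydrogen in place of ethyl on a saturated chain carbon, eight bonds along the chain from a triple-bonded carbon), which gave a 1.7-fold higher number from compound 2 to compound 3 (0.24 log units; within the scatter), again a step within the scatter. Taken together, the three numbers in this assay lie close to one another, and none of the compounds can be called more or less toxic than the others on this evidence.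

Compound 4 `CCCCCCCCC#Cc1cc2cn([C@@H]3O[C@H](CO)[C@@H](O)[C@H]3O)c(=O)nc2o1` has not yet been measured. It differs from compound 3 by the change (hydroxy in place of hydrogen on a saturated ring carbon), which is the same change that leads from compound 2 to compound 1, placed on the same ring in the same surroundings, while the chain of compound 4 is that of compound 3. Among the compounds with values here, since the one earlier example of this change, a 1.5-fold higher number from compound 2 to compound 1 (0.19 log units; within the scatter), stayed within the scatter, a step of similar size is expected for compound 4 in this assay, namely a 1.4-fold higher number from compound 3 to compound 4 (0.16 log units; within the scatter), resting on that single precedent and on the value of compound 3, 52000 nM. Compound 4 is therefore estimated to give 75000 nM in this assay, with a plausible range from 35000 nM to 160000 nM.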

Compound 4, minimum cytotoxic concentration: 49000 nM
Beside the measured number, compound 4's estimate is 1.5-fold (0.18 log units) above it; measured number inside the range.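

In this assay, hydroxy in place of hydrogen on a saturated ring carbon gave a 1.1-fold lower number from compound 3 to compound 4 (0.03 log units; within the scatter), so the change stayed within the scatter on the shorter chain of compound 3 as it had on the longer chain of compound 2, and the two steps do not differ: the same change on two cores in this assay, a 1.5-fold higher number (0.19 log units; within the scatter) from compound 2 to compound 1 and a 1.1-fold lower number (0.03 log units; within the scatter) from compound 3 to compound 4, 1.6-fold (0.21 log units) apart, within the scatter of two such steps

This shows that, across these two pairs, the change carries from one core to the other without a readable effect on this read-out, and the opposite directions of the two steps cannot be taken as a reversal. It does not show that the change is without effect in general, since it rests on two pairs only, and the structures as drawn carry the new hydroxy with opposite stereochemistry in compound 1 and compound 4, so the two steps are not strictly the same change.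

The compounds shown leave open whether the same result would hold with a much shorter chain or a phenyl group in place of the alkyl chain. They also leave open what an amine or a fluorine in place of the new hydroxy on that ring carbon would do to the number.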